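A few compounds are considered here, and "the series" means these few. Any claim that something is new, unique, unknown or untested is made for them only; others in the source may bear on it.

Measured so far in a functional assay on KB 3-1 cells (Homo sapiens) for cytotoxicity, read by MTT assay, with a stated time of 68 h; a lower number here means a stronger inhibitor, a higher number a weaker inhibitor:
Compound 1 `O=C(Nc1cccc(-c2cccc(F)c2)c1)C(Cl)Cl`: > 50000 nM
Compound 2 `O=C(Nc1cccc(-c2ccc(-c3ccccc3)cc2)c1)C(Cl)Cl`: > 50000 nM
Compound 3 `O=C(Nc1cccc(-c2cccs2)c1)C(Cl)Cl`: > 50000 nM

Compound 1 gives no number in this assay: its reading of > 50000 nM is a limit of the assay. Compound 2 likewise returns only a limit, > 50000 nM. Compound 3 also returns only a limit, > 50000 nM. The three readings coincide, with the limit of > 50000 nM in this assay, at which 3 of the 3 values shown sit, so no order can be drawn among these compounds and no measured step is available to set a scale.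

Compound 4 `O=C(Nc1cccc(-c2cccc(Cl)c2)c1)C(Cl)Cl` has not yet been measured. It departs from compound 1 by a single exchange, chloro in place of fluoro on an aromatic carbon, meta to a large group. In this assay, no step beyond the usual scatter is expected from this exchange, in either direction, and a further reading at the same limit is the most likely result. This expectation rests on compound 1, whose reading is the limit > 50000 nM. The step expected is a number no higher from compound 1 to compound 4 (the limit leaves the size open), which is an estimate only. For compound 4 the estimated value is 50000 nM, with an expected range from 25000 nM to 100000 nM.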

Compound 4, half-maximal inhibitory concentration: > 50000 nM
Compound 4: only a limit was reported; the forecaster's own chance of this, stated with the estimate: 85%; the middle value lies on the limit itself.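

Compound 4 returns only a limit in this assay, > 50000 nM. Compound 1 also stands at a limit, so chloro in place of fluoro gives no readable step between compound 1 and compound 4: the limit of > 50000 nM in this assay, at which 4 of the 4 values shown sit. The compounds shown leave open whether any of them would give a measurable value in this assay, and how large a step this exchange could produce.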